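From a Carbonyl-Linked Ring to a Two-Oxygen Ring

This account rests on a few compounds, and the source may have more. Where it says the series, first, only, none or still open, it means among the compounds named here.

Compound 1 `Cc1cc(C)c(S(=O)(=O)N2CCC(N3CC(C)CC(C)C3)CC2)c(C)c1`: 17 nM
Compound 2 `CCCC(=O)NC1CCN(S(=O)(=O)c2c(C)cc(C)cc2C)CC1`: > 5000 nM (a limit of the assay)
Compound 3 `Cc1cc(C)c(S(=O)(=O)N2CCC(C(=O)N3CCC(C)CC3)CC2)c(C)c1`: > 5000 nM (a limit of the assay)

In a functional assay on DLD-1 cells (Homo sapiens) for antiproliferative activity, read by CellTiter-Glo, with a stated time of 72 h (a lower number here means a stronger inhibitor, a higher number a weaker inhibitor), compound 1 gives 17 nM. For compound 2 the assay reports only a limit, > 5000 nM. For compound 3 the assay likewise reports only a limit, > 5000 nM. Compound 3 therefore stands at the limit of > 5000 nM in this assay, at which 2 of the 3 values shown sit, and no number is known for it. The two measured steps away from compound 1 are both large: an at least 290-fold higher number from compound 1 to compound 2 (2.46 log units; beyond the scatter), and an at least 290-fold higher number from compound 1 to compound 3 (2.46 log units; beyond the scatter). Between the two limits, a step that the two limits leave unreadable from compound 2 to compound 3.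

Compound 4 `Cc1cc(C)c(S(=O)(=O)N2CCC(C3OCC(C)CO3)CC2)c(C)c1` differs from compound 3 by a group of 7 heavy atoms (5 carbon, 2 oxygen; one six-membered non-aromatic ring with 2 hetero atoms) in place of a group of 9 heavy atoms (7 carbon, 1 nitrogen, 1 oxygen; one six-membered non-aromatic ring with 1 hetero atom), on a saturated ring carbon. Like compound 2 and compound 3, compound 4 lacks the 3,5-dimethylpiperidin-1-yl group whose removal from compound 1 produced both large steps. On that basis compound 4 is expected to remain at the limit, an estimated step that the limit leaves unreadable from compound 3 to compound 4. The estimate for compound 4 is 6000 nM, within a range of 1500 nM to 20000 nM, most likely reported again only as a limit.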

Compound 4, half-maximal inhibitory concentration: > 5000 nM
Compound 4 gave a limit, no number (the forecaster's own chance of this, stated with the estimate: 70%); the middle value lies beyond the limit too.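

In this assay compound 4 gives only a limit, so a ring with two oxygens on this saturated ring carbon ends where the earlier replacements of the 3,5-dimethylpiperidin-1-yl group ended: the limit of > 5000 nM in this assay, at which 3 of the 4 values shown sit.
The earlier compounds showed this only for replacements that carry a carbonyl, and compound 4 has none, so the loss does not depend on that feature among the compounds shown.
The large step appears a third time, as an at least 290-fold higher number from compound 1 to compound 4 (2.46 log units; beyond the scatter), while the steps from compound 2 and compound 3 to compound 4 cannot be read, as both ends are limits.

From the compounds shown here alone, whether a smaller amine on this carbon, such as piperidin-1-yl or dimethylamino, would bring back a measurable number stays open.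
So does how compound 2, compound 3 and compound 4 rank beyond the limit.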